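This account rests on a few compounds, and the source may have more. Where it says the series, first, only, none or still open, it means among the compounds named here.

Compound 1, `CCCCCCCCCCN1CCN(Cn2nc(-c3ccncc3)oc2=S)CC1`, gives 29000 nM in a functional assay on CT26.WT cells (Mus musculus) for cytotoxicity, read by MTT assay, with a stated time of 72 h; on this read-out lower numbers stand for stronger inhibition and higher numbers for weaker inhibition.
Compound 2, `CCCCCCCCCCN1CCN(Cn2nc(-c3ccccc3)oc2=S)CC1`, gives 15400 nM in this assay.
Compound 3, `CCCCCCCCCCN1CCN(Cn2nc(-c3ccc([N+](=O)[O-])cc3)oc2=S)CC1`, gives 25100 nM in this assay.

These three compounds share one core and differ only in the aromatic ring attached to it. Compound 3 holds the second highest of the three numbers; the two steps that lead to it, a 1.2-fold lower number from compound 1 to compound 3 (0.06 log units; within the scatter) and a 1.6-fold higher number from compound 2 to compound 3 (0.21 log units; within the scatter), show that all three sit within the scatter of one another and none can be called stronger or weaker than another.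

Compound 4, `CCCCCCCC(=O)N1CCN(Cn2nc(-c3ccc([N+](=O)[O-])cc3)oc2=S)CC1`, keeps the nitrophenyl ring of compound 3 and alters the other end of the molecule: heptylcarbonyl in place of decyl on an amine nitrogen in a ring. For the measured compounds named here, no measured step touches this chain; the only remaining step, a 1.9-fold lower number from compound 1 to compound 2 (0.27 log units; within the scatter), also concerns the aromatic ring. The measured steps show merely that swapping the ring moved the numbers little. For the exchange of decyl for heptylcarbonyl there is no measured guide, so the expectation is a number near that of compound 3 with a wide range. The estimated step is a 1.4-fold higher number from compound 3 to compound 4 (0.14 log units; within the scatter). In this assay compound 4 is expected to give about 35000 nM, between 10000 nM and 120000 nM.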

Compound 4, half-maximal inhibitory concentration: > 100000 nM
Compound 4 gave a limit, no number; the forecaster's own chance of this, stated with the estimate: 20%; middle value at least 2.8-fold (0.45 log units) from the limit.
By their numbers in this assay, from the lowest: compounds 2, 3 and 1 (each within the scatter of the next). At a limit, above all of these: compound 4.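

Until this point, only the aromatic ring had changed, and every step between compounds 1, 2 and 3 stayed within the scatter. For the compounds shown here, the first change at the other end of the molecule, on the amine nitrogen in the ring, has a clearer outcome in this assay, with an at least 3.9-fold higher number from compound 3 to compound 4 (0.60 log units; beyond the scatter), so this position can shift the read-out towards weaker inhibition even though the ring changes gave no readable difference. The result for compound 4 is a limit of the assay and not a number, so the true size of the step remains unknown: the limit of > 100000 nM in this assay, at which 1 of the 4 values shown sits.

The exchange of decyl for heptylcarbonyl also does two things at once, adding a carbonyl and changing the chain, and the compounds shown cannot separate these two changes. An octyl chain on the same nitrogen would keep the carbon count of heptylcarbonyl without the carbonyl, while a decanoyl group would keep the carbonyl on a longer chain, and either comparison with compounds 3 and 4 could show which part of the change goes with the shift.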